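This account rests on a few compounds, and the source may have more. Where it says the series, first, only, none or still open, it means among the compounds named here.

Working notes on the series. Three compounds have numbers in an assay on a protein complex for inhibition of CDK8/Cyclin C (Homo sapiens), with a stated time of 1 h, tested at 10 uM; a higher number here means more inhibition at the concentration tested (going by the name of the read-out), a lower number less inhibition. Compound 1 `CC(C)[C@@H](NC(=O)/C=C/c1ccncc1-c1ccc2ccccc2c1)C(=O)O` gives 77% in this assay. Compound 2 `CNC(=O)/C=C/c1ccncc1-c1ccc2[nH]ccc2c1` gives 100%, and compound 3 `COc1ccc(-c2cnccc2/C=C/C(=O)N2CC(OC)C2)cc1OC` gives 87%. Compound 1 stands lowest of the three: its nearest is compound 3, a gap within the usual scatter, and its furthest is compound 2, a gap beyond it.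

Compound 4 `O=C(/C=C/c1ccncc1-c1ccc2ccccc2c1)NC1CC1` differs from compound 1 in one place: cyclopropyl in place of 1-carboxy-2-methylpropyl on an amide-type nitrogen. Going by the values given here, no measured pair shows this same change, so the size of the step is not known from the data. The step from compound 1 to compound 4, expected as a number 11 percentage points higher from compound 1 to compound 4 (beyond the scatter), is taken as a moderate rise, at the edge of the scatter, since compounds 2 and 3 with other amide substituents both give higher numbers. Compound 4 is thus expected to give 88%, within a range from 70% to 100%.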

Compound 4, a percentage reported as inhibition, at one concentration (the size of the read-out at that concentration, not a potency): 102%
For compound 4 the middle estimate is 14 percentage points below the measured one; the measured number lies above the stated range.
By their numbers in this assay, from the lowest: compounds 1 and 3 (each within the scatter of the next); then compounds 2 and 4 (each within the scatter of the next).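

Cyclopropyl in place of 1-carboxy-2-methylpropyl on an amide-type nitrogen gives a number 25 percentage points higher from compound 1 to compound 4 (beyond the scatter) in this assay and is the first reading of a single change at this position. The change removes the carboxy group, the branched chain and the defined stereocentre together, so this one step cannot assign the rise to any of these parts. No measurement at hand gives a reason for the step.

Open, from the compounds shown here alone, is whether a methyl ester, a carboxylic acid on a shorter chain or an isopropyl group on this nitrogen would read like compound 1 or like compound 4.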